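The source may hold more compounds than are shown below. What is called first, only, known or untested is meant among the compounds shown, and "the series" means these compounds.

Series notes. Compound 1 `CN(C)CCCCCn1c2c(c3ccccc31)C(=O)c1c[n+]([O-])c3ccccc3c1C2=O` and compound 2 `CC1(C)OC[C@H](Cn2cc(Cn3c4c(c5ccccc53)C(=O)c3c[n+]([O-])c5ccccc5c3C4=O)nn2)O1` share a core and differ in the chain on the aromatic nitrogen. In a toxicity assay on L02 cells (Homo sapiens) for cytotoxicity, read by MTT assay, with a stated time of 72 h (a lower number here means a stronger inhibitor, a higher number a weaker inhibitor), compound 1 gives 240 nM; in this assay compound 2 gives 470 nM. Among the compounds with values here, of the two numbers so far, compound 1 is the one taken as reference, but its gap to compound 2 lies within the usual scatter, so the pair is not separable.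

Compound 3 `O=C1c2c[n+]([O-])c3ccccc3c2C(=O)c2c1c1ccccc1n2CCCCN1CCCCC1` keeps the core of compound 1 with one change: piperidin-1-yl in place of (dimethylamino)methyl on a saturated chain carbon, four bonds along the chain from an aromatic nitrogen. Within the data shown here, no measured pair shows this change. The expectation is that the step from compound 1 to compound 3 a 1.1-fold higher number from compound 1 to compound 3 (0.03 log units; within the scatter) stays within the scatter, in no clear direction. Compound 3 is estimated at 260 nM, in the range 110 nM to 650 nM.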

Compound 3, half-maximal inhibitory concentration: 610 nM
For compound 3 the middle estimate is 2.3-fold (0.37 log units) below the measured one; the measured number falls inside the stated range.
By their numbers in this assay, from the lowest: compounds 1, 2 and 3 (each within the scatter of the next, the first and the last beyond it).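

In this assay, within the data shown here, piperidin-1-yl in place of (dimethylamino)methyl on a saturated chain carbon, four bonds along the chain from an aromatic nitrogen, gives a 2.5-fold higher number from compound 1 to compound 3 (0.41 log units; beyond the scatter) as the first step beyond the scatter. The end of this chain can therefore move the number, though modestly and on a single pair. No measured data on hand account for this step.

The compounds shown leave open whether a pyrrolidine or morpholine at the chain end, or a longer chain carrying piperidin-1-yl, would move the number the same way.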